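Removing the Last Methyl from the Amine Nitrogen

The source may hold more compounds than are shown below. What is called first, only, known or untested is meant among the compounds shown, and "the series" means these compounds.

Among the measured compounds shown here, in an ADME assay on the whole organism (Rattus norvegicus, strain Sprague-Dawley) for metabolic stability, read by LC-MS, with a stated time of 24 h, at a dose of 2 mg/kg by the intravenous route (a lower number here means that the compound disappears faster, a higher number that the compound lasts longer), compound 2 `CNCc1ccc(-c2c3ncn(CC4(O)CCN(Cc5ccc(-c6ccco6)cc5Cl)CC4)c(=O)c3nn2C)cc1` gives 13.8 h, the higher of the two numbers measured so far. For the measured compounds named here, the only comparison is compound 1 `Cn1nc2c(=O)n(CC3(O)CCN(Cc4ccc(-c5ccco5)cc4Cl)CC3)cnc2c1-c1ccc(CNC=O)cc1`, which gives 5.7 h and carries a formyl group on the same amine nitrogen. That single measured step, a 2.4-fold higher number from compound 1 to compound 2 (0.38 log units; beyond the scatter), is modest and replaces formyl with methyl.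

The next structure is compound 3 `Cn1nc2c(=O)n(CC3(O)CCN(Cc4ccc(-c5ccco5)cc4Cl)CC3)cnc2c1-c1ccc(CN)cc1`, which has hydrogen in place of methyl on an amine nitrogen. Its 4-((methylamino)methyl)phenyl group thus becomes 4-(aminomethyl)phenyl. Going by the values given here, the measured step touches the same nitrogen but exchanges a different pair of groups, so it shows only that changes at this place can move this assay. It does not give the direction of the new change. Among the compounds with values here, no measured compound carries the aminomethyl group, and the evidence is therefore indirect.

A slight fall, not beyond the scatter, is expected, and the estimate means a 1.3-fold lower number from compound 2 to compound 3 (0.10 log units; within the scatter). The half-life of compound 3 is estimated at 11 h, with an expected range of 5.5 h to 22 h.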

Compound 3, half-life: 1.7 h
Estimate against measurement, compound 3: 6.5-fold (0.81 log units) above; measured number below the stated range.
By their numbers in this assay, from the lowest: compound 3; then compound 1; then compound 2.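

In this assay, the earlier step showed only that exchanging formyl for methyl on this amine nitrogen raises the number, while the new result shows what happens when the nitrogen keeps neither group: removing the methyl gives an 8.1-fold lower number from compound 2 to compound 3 (0.91 log units; beyond the scatter). Hydrogen also compares poorly with formyl, with a 3.4-fold lower number from compound 1 to compound 3 (0.53 log units; beyond the scatter), so the two substituted compounds both stand above the compound with the free aminomethyl group, and all three steps on this nitrogen lie beyond the scatter. Among these three compounds the order on the nitrogen therefore runs from hydrogen through formyl to methyl, with no compound going against it, although no measurement here says what lies behind that order.

The compounds shown leave open whether a second methyl on the same nitrogen, an ethyl group or a longer chain would continue the rise seen with methyl or reverse it. They also leave open where an acetyl group would fall relative to formyl, and whether the same order would hold if the nitrogen were part of a ring such as a pyrrolidine.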